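Adding an Arginine-Type Side Chain to Compound 2

The source may hold more compounds than are shown below. What is called first, only, known or untested is meant among the compounds shown, and "the series" means these compounds.

Of the compounds shown here, three have been tested in a functional assay on the whole organism (Tail, strain ICR) with Mus musculus as the target, in the tail flick test, with a stated time of 150 min, at a dose of 25 umol/kg by the oral route; a lower number here means a weaker effect, a higher number a stronger effect of the compound at the dose given. Compound 1 `O=C(O)[C@@H]1CCCN1C(=O)CN(c1nc(Cl)nc2[nH]cnc12)C1CC1` gives 7.29%, compound 2 `O=C(CN(c1nc(Cl)nc2[nH]cnc12)C1CC1)NCC(=O)OCc1ccccc1` gives 18%, and compound 3 `O=C(CN(c1ncnc2c1ncn2C1CCCCO1)C1CC1)N[C@@H](CCC(=O)OCc1ccccc1)C(=O)OCc1ccccc1` gives 14.1%. Compound 2 stands above compound 1 by more than the usual scatter, while its number and that of compound 3 lie within the scatter of each other, so no order between those two can be claimed.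

Compound 4 `N=C(N)NCCC[C@H](NC(=O)CN(c1nc(Cl)nc2[nH]cnc12)C1CC1)C(=O)OCc1ccccc1` differs from compound 2 by a group of 7 heavy atoms (4 carbon, 3 nitrogen; no ring) in place of a hydrogen atom, on a saturated chain carbon bound to an amide-type nitrogen and a carbonyl carbon. Among the compounds with values here, no measured pair shows the effect of such a change, so the expected step in this assay is none beyond the scatter, in either direction. The estimated value for compound 4 is 17%, with a range from 5% to 32%, which means an expected step of a number 1 percentage points lower from compound 2 to compound 4 (within the scatter).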

Compound 4, a percentage reported as activity, at one dose (the size of the read-out at that dose, not a potency): 6.12%
Compound 4: the middle estimate sits 10.9 percentage points above what was measured, within the range that was stated.
By their numbers in this assay, from the lowest: compounds 4, 1, 3 and 2 (each within the scatter of the next, the first and the last beyond it).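

In this assay, a group of 7 heavy atoms in place of a hydrogen atom, on a saturated chain carbon bound to an amide-type nitrogen and a carbonyl carbon, gives a number 11.9 percentage points lower from compound 2 to compound 4 (beyond the scatter) and so shows that this position is sensitive to change. Within the data shown here, this is the first step in the set that isolates a single place, and it goes downward. Nothing measured here explains the drop. Going by these compounds, whether a methyl group, or a chain ending in an amine or a carboxylic acid, would lower the number too remains open, and so does whether the length of the chain or its end matters.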